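The compounds below may be only part of what the source reports. "The series", "measured", "known", "first", "only" and "open" are said of these compounds alone.

The measured compounds, each in an assay on isolated protein for inhibition of alpha-galactosidase (Coffea arabica), tested at 1000 uM; a lower number here means less inhibition, a higher number more inhibition at the concentration tested (going by the name of the read-out):

Compound 1, `OC[C@@]1(c2ccc(F)cc2)NC[C@@H](O)[C@@H]1O`: 0%
Compound 2, `COc1ccc([C@]2(CO)NC[C@@H](O)[C@@H]2O)cc1`: 7.5%

Compound 2 carries the higher of the two numbers, but it cannot be told apart from compound 1: the step of a number 7.5 percentage points higher from compound 1 to compound 2 (within the scatter) lies within the scatter, so the two compounds stand level in this assay.

Compound 3, `OC[C@@]1(c2ccc(O)cc2)NC[C@@H](O)[C@@H]1O`, is the next member. It differs from compound 2 only in that (hydrogen in place of methyl on an oxygen on an aromatic ring). For the measured compounds named here, the one measured step, from compound 1 to compound 2, concerns the same aromatic position but a different exchange, and it was small; no step from methoxy to hydroxy has been measured, so nothing in the data points to a move beyond the scatter. Compound 3 is therefore expected to stay close to compound 2, with a step of about a number 2.5 percentage points lower from compound 2 to compound 3 (within the scatter). The estimate for compound 3 in this assay is 5%, within a range from 0% to 15%.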

Compound 3, a percentage reported as inhibition, at one concentration (the size of the read-out at that concentration, not a potency): 1.2%
Compound 3: middle estimate off by 3.8 percentage points, on the high side; the range from low to high includes it.
By their numbers in this assay, from the lowest: compounds 1, 3 and 2 (each within the scatter of the next).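

In this assay, putting hydrogen in place of methyl on the oxygen on the aromatic ring gives a number 6.3 percentage points lower from compound 2 to compound 3 (within the scatter) and adds a second exchange at this place, while hydroxy in place of fluoro on the aromatic carbon gives a number 1.2 percentage points higher from compound 1 to compound 3 (within the scatter) and closes the set of comparisons among the three groups. Fluoro, methoxy and hydroxy therefore all stand level here, so removing the methyl leaves compound 3 indistinguishable from both compound 2 and compound 1. No independent evidence bears on this result.

As far as these compounds go, whether an amine or a carboxylic acid on this aromatic carbon, or a longer chain on the oxygen in place of methyl, would give a step beyond the scatter remains open. So does whether any group at this place can raise the inhibition clearly above that of these three compounds.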